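A few compounds are considered here, and "the series" means these few. Any claim that something is new, unique, unknown or untested is made for them only; others in the source may bear on it.

Measured so far:
compound 1 `CCO/C(O)=C1\C(COCCn2ccnn2)=NC(C)=C(C(=O)OC)C1c1cccc(Cl)c1Cl` — 5.01 nM
compound 2 `CCO/C(O)=C1\C(COCCn2cc(N)nc2O)=NC(C)=C(C(=O)OC)C1c1ccccc1Cl` — 31.6 nM
compound 3 `CCO/C(O)=C1\C(COCCn2c(N)cnc2O)=NC(C)=C(C(=O)OC)C1c1ccccc1Cl` — 158 nM

In a functional assay (aorta) with Rattus norvegicus as the target (on this read-out lower numbers stand for stronger inhibition and higher numbers for weaker inhibition), compound 1 gives the lowest of the three numbers, with compound 2 next and compound 3 furthest off. Compound 4 `CCO/C(O)=C1\C(COCCN2CC(=O)NC2=O)=NC(C)=C(C(=O)OC)C1c1cccc(Cl)c1Cl` is compound 1 with 2,4-dioxoimidazolidin-1-yl in place of 1H-1,2,3-triazol-1-yl on a saturated chain carbon, two bonds along the chain from an oxygen on a saturated carbon. For the measured compounds named here, no measured step covers this exact exchange. Going by the values given here, the only step available, a 5.0-fold higher number from compound 2 to compound 3 (0.70 log units; beyond the scatter), swaps two ring substituents on a different side-chain ring, and compounds 2 and 3 also carry a different aryl group than compound 1, so it bears only loosely here. Exchanging the aromatic ring for a non-aromatic one is expected to cost some potency, giving an estimated step of a 3.0-fold higher number from compound 1 to compound 4 (0.48 log units; beyond the scatter) in this assay. Compound 4 is therefore expected to give about 15 nM, most likely between 4 nM and 60 nM.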

Compound 4, half-maximal inhibitory concentration: 3.16 nM
The estimate for compound 4 lay 4.7-fold (0.68 log units) above the measured number; the measured number lies below the stated range.
By their numbers in this assay, from the lowest: compounds 4 and 1 (each within the scatter of the next); then compound 2; then compound 3.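

In this assay, the change at the end of the chain gives a 1.6-fold lower number from compound 1 to compound 4 (0.20 log units; within the scatter), so the aromatic 1H-1,2,3-triazol-1-yl ring and the non-aromatic 2,4-dioxoimidazolidin-1-yl ring cannot be told apart at this position. For this pair, then, an aromatic ring is not required there for a low number, and the added carbonyl groups and the amide hydrogen leave the read-out within the scatter. No measurement here offers an explanation for this match.

Still open, as far as these compounds go, is how a group without a ring, such as a simple amine or a carboxylic acid, would read at this place. A longer chain carrying the 2,4-dioxoimidazolidin-1-yl ring is also an open case.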